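The source may report more compounds than this note shows. Statements on the series, on what has been measured and on what is new or still open speak of the compounds shown alone.

Compound 3 `Cc1ccc2oc(SCC(=O)Nc3ccc(-c4nc(-c5ccccc5)c(-c5ccccc5)n4C)cc3)nc2c1` gives 65.1% in a functional assay on MCF7 cells (Homo sapiens) for cytotoxicity, read by MTT assay, with a stated time of 24 h, tested at 80 ug/mL; a higher number here means a stronger effect of the compound at the concentration tested, a lower number a weaker effect. Among the three compounds measured so far, compound 3 stands lowest: compound 1 `Cn1c(-c2ccc(NC(=O)CCl)cc2)nc(-c2ccccc2)c1-c1ccccc1` gives 70%, and compound 2 `Cn1c(-c2ccc(NC(=O)CSc3nc4ccccc4o3)cc2)nc(-c2ccccc2)c1-c1ccccc1` gives 76.3%. The step of a number 4.9 percentage points lower from compound 1 to compound 3 (within the scatter) and the step of a number 6.3 percentage points higher from compound 1 to compound 2 (within the scatter) both lie within the scatter, whereas a number 11.2 percentage points lower from compound 2 to compound 3 (beyond the scatter) lies beyond it. Compound 4 `Cn1c(-c2ccc(NC(=O)CSc3nc4ccccc4s3)cc2)nc(-c2ccccc2)c1-c1ccccc1` differs from compound 3 by 1,3-benzothiazol-2-yl in place of 5-methyl-1,3-benzoxazol-2-yl on a sulfur. Going by the values given here, no measured step exchanges the oxygen of that group for sulfur, so this part of the change cannot be weighed from the numbers at hand. The loss of the methyl, however, mirrors in reverse the step of a number 11.2 percentage points lower from compound 2 to compound 3 (beyond the scatter), which points to a modest rise. Since all three measured values lie close together, compound 4 is expected to return to the upper part of that span, with a moderate step expected: a number 7.9 percentage points higher from compound 3 to compound 4 (within the scatter). Compound 4 is therefore estimated at 73%, with a range from 62% to 84%.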

Compound 4, a percentage reported as activity, at one concentration (the size of the read-out at that concentration, not a potency): 76.6%
Estimate against measurement, compound 4: 3.6 percentage points below; measured number inside the range.
By their numbers in this assay, from the lowest: compounds 3, 1, 2 and 4 (each within the scatter of the next, the first and the last beyond it).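

In this assay, going by these compounds alone, the step of a number 0.3 percentage points higher from compound 2 to compound 4 (within the scatter) gives the exchange of 1,3-benzoxazol-2-yl for 1,3-benzothiazol-2-yl on a sulfur a measured size for the first time, and that size does not separate the two groups. Within the data shown here, the step of a number 11.5 percentage points higher from compound 3 to compound 4 (beyond the scatter) then leaves compound 3, the only compound here carrying the 5-methyl group, beyond the scatter of both compound 2 and compound 4, although it stays within the scatter of the chloro compound 1. With a number 6.6 percentage points higher from compound 1 to compound 4 (within the scatter), replacing chloro with (1,3-benzothiazol-2-yl)sulfanyl, like the matching benzoxazole exchange, stays within the scatter.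

The compounds shown leave open whether a methyl on the 1,3-benzothiazol-2-yl group would bring a similar drop, and what an amine or a carboxylic acid in place of chloro on that chain carbon would do. No evidence is available to explain any of these steps.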